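The source may report more compounds than this note shows. Statements on the series, on what has been measured and on what is new or still open speak of the compounds shown alone.

Three compounds were measured in an assay on frontal cortex for displacement of a labelled ligand from corticotropin-releasing factor receptor 1 (Rattus norvegicus), with a stated time of 2 h; a higher number here means a weaker inhibitor, a lower number a stronger inhibitor:

Compound 1, `COc1nc(C)c(Nc2nc(Cl)cn([C@H](CO)C3CC3)c2=O)cc1C`: 88 nM
Compound 2, `COc1nc(C)c(Nc2nc(Cl)cn([C@H](COC(=O)c3ccccc3)C3CC3)c2=O)cc1C`: 1.5 nM
Compound 3, `COc1nc(C)c(Nc2nc(Cl)cn([C@H](COC(=O)Nc3ccccc3Cl)C3CC3)c2=O)cc1C`: 1.5 nM

Compound 3 stands level with compound 2 at the digits given, the two together at the low end of the three numbers; the gap to compound 1 is the step of a 59-fold lower number from compound 1 to compound 3 (1.77 log units; beyond the scatter). Compound 4, `COc1nc(C)c(Nc2nc(Cl)cn([C@H](COC(=O)Nc3ccc(Cl)cc3Cl)C3CC3)c2=O)cc1C`, differs from compound 3 by chloro in place of hydrogen on an aromatic carbon. Among the measured compounds shown here, no measured step alters a substituent on that terminal ring. The nearest comparison is no change at the digits printed from compound 2 to compound 3 (within the scatter), where the whole terminal group was exchanged without moving the number, while the large steps of a 59-fold lower number from compound 1 to compound 2 (1.77 log units; beyond the scatter) and a 59-fold lower number from compound 1 to compound 3 (1.77 log units; beyond the scatter) concern the ester or carbamate itself, which compound 4 keeps. A step within the scatter is therefore expected, a 1.2-fold higher number from compound 3 to compound 4 (0.08 log units; within the scatter). Compound 4 is estimated at 1.8 nM, between 0.6 nM and 6 nM.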

Compound 4, half-maximal inhibitory concentration: 1.7 nM
Compound 4: middle estimate off by 1.1-fold (0.02 log units), on the high side, and the stated range covers the measured number.
By their numbers in this assay, from the lowest: compounds 2, 3 and 4 (each within the scatter of the next); then compound 1.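

In this assay, among the compounds shown here, chloro on the aromatic carbon para to a large group, the first change on the terminal ring itself, leaves the number within the scatter (a 1.1-fold higher number from compound 3 to compound 4 (0.05 log units; within the scatter)). The (2,4-dichlorophenyl)carbamoyl group also stays within the scatter of the benzoyl ester (a 1.1-fold higher number from compound 2 to compound 4 (0.05 log units; within the scatter)) and keeps the large distance from the free hydroxyl (a 52-fold lower number from compound 1 to compound 4 (1.71 log units; beyond the scatter)). No evidence at hand explains why the number holds at this position. The compounds shown leave open whether methoxy, a dimethylamino group or a carboxylic acid on this same carbon would leave the number equally unmoved.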